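Phenyl for benzyl on a thiourea pair

The source may report more compounds than this note shows. Statements on the series, on what has been measured and on what is new or still open speak of the compounds shown alone.

Compound 1 `CC(C)[C@H](NC(=S)Nc1ccccc1)c1nc2ccccc2[nH]1` gives 5200 nM
Compound 2 `C[C@H](NC(=S)NCc1ccccc1)c1nc2ccccc2[nH]1` gives "not active" (no number reported)

Both compounds were tested in a functional assay on A549 cells (Homo sapiens) for cytotoxicity, read by MTT assay (on this read-out lower numbers stand for stronger inhibition and higher numbers for weaker inhibition), and only compound 1 returned a number. Compound 2 has no place on the numerical scale, since its result reads "not active" (no number reported) in place of a value. The compound still to be measured in this assay is compound 3 `C[C@H](NC(=S)Nc1ccccc1)c1nc2ccccc2[nH]1` and its structure departs from that of compound 2 in one place. The change is phenyl in place of benzyl on an amide-type nitrogen and it puts phenyl in place of benzyl on an amide-type nitrogen.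

Among the measured compounds shown here, no measured step shows what this exchange does, and compound 2 offers no number to step from. A size therefore cannot be stated, only a direction. A measurable value is expected, which would be stronger inhibition than compound 2 showed, though compound 3 may also return no number. The only figure available is that of compound 1 at 5200 nM and a somewhat weaker result than this is expected. Compound 3 is estimated at 20000 nM in this assay with an expected range of 6000 nM to 80000 nM on this reasoning.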

Compound 3, half-maximal inhibitory concentration: 188000 nM
Beside the measured number, compound 3's estimate is 9.4-fold (0.97 log units) below it, outside the stated range (above it).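

In this assay compound 3 returns a number (188000 nM), so the exchange of benzyl for phenyl on the amide-type nitrogen leaves a compound with a reading on the scale, although the step from compound 2 cannot be read, as compound 2 has no number to start from. The clearer information concerns the saturated chain carbon: with phenyl held constant on the nitrogen, methyl in place of isopropyl gives a 36-fold higher number from compound 1 to compound 3 (1.56 log units; beyond the scatter), which shows that the group on this carbon strongly affects the reading and that the isopropyl compound is the stronger of this pair. Nothing shown here accounts for the size of this step.

The compounds shown leave open whether benzyl on the amide-type nitrogen would return a number if isopropyl stood on the chain carbon, a pairing that would put the phenyl and benzyl exchange on a numerical footing. They also leave open how a longer chain such as n-butyl or a ring such as cyclohexyl on the chain carbon would read against methyl and isopropyl.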